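Swapping an aryl group on a piperazine: two matched pairs

This account rests on a few compounds, and the source may have more. Where it says the series, first, only, none or still open, it means among the compounds named here.

Of the compounds shown here, three have been measured in an assay on CHO cells for displacement of a labelled ligand from 5-hydroxytryptamine receptor 7 (Homo sapiens), read by scintillation counting, with a stated time of 60 min; a higher number here means a weaker inhibitor, a lower number a stronger inhibitor. Compound 1 `COc1ccc(/C=C2\NC(=O)N(CCCCN3CCN(c4ccccc4OC)CC3)C2=O)cc1OC` gives 16 nM in this assay. Compound 2 `COc1ccc(/C=C2\NC(=O)N(CCCCN3CCN(c4cccc(Cl)c4Cl)CC3)C2=O)cc1OC` gives 0.8 nM. The two differ in one place only, marked by 2,3-dichlorophenyl in place of 2-methoxyphenyl on an amine nitrogen in a ring, and this change made the step of a 20-fold lower number from compound 1 to compound 2 (1.30 log units; beyond the scatter). Compound 3 `COc1ccc(/C=C2\NC(=O)N(CCCN3CCN(c4ccccc4OC)CC3)C2=O)cc1OC1CCCC1` gives 6 nM; it shares the aryl group of compound 1 but sits on a different core, and the difference between the two cores is not broken down here. Among the three, compound 3 stands between the others: its number is lower than that of compound 1 and higher than that of compound 2.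

Compound 4 `COc1ccc(/C=C2\NC(=O)N(CCCN3CCN(c4cccc(Cl)c4Cl)CC3)C2=O)cc1OC1CCCC1` has not yet been measured. It is built from compound 3 by the same change that turned compound 1 into compound 2, namely (2,3-dichlorophenyl in place of 2-methoxyphenyl on an amine nitrogen in a ring); the place of the change is described in the same words for both pairs. The expectation for compound 4 therefore rests on one earlier example. Going by the values given here, since the change from compound 1 to compound 2 produced a 20-fold lower number from compound 1 to compound 2 (1.30 log units; beyond the scatter), a step of similar direction is expected here, estimated at a 12-fold lower number from compound 3 to compound 4 (1.08 log units; beyond the scatter), though with only one precedent its size is uncertain. Compound 4 is expected to give about 0.5 nM in this assay, most likely between 0.15 nM and 2 nM.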

Compound 4, inhibition constant: 380 nM
Compound 4: the middle estimate sits 760-fold (2.88 log units) below what was measured; the whole stated range lies below it.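

Measured in this assay, the same swap that strengthened binding on the core of compound 1 gave a 63-fold higher number from compound 3 to compound 4 (1.80 log units; beyond the scatter), so the change did not even keep its direction when carried to the second core: the same change on two cores in this assay, a 20-fold lower number (1.30 log units; beyond the scatter) from compound 1 to compound 2 and a 63-fold higher number (1.80 log units; beyond the scatter) from compound 3 to compound 4, 1300-fold (3.10 log units) apart, beyond the scatter of two such steps. In this series, then, a result for 2,3-dichlorophenyl in place of 2-methoxyphenyl on one core cannot be assumed to hold on another, and a single earlier pair is a weak basis for predicting the next one. These two pairs do not show why the direction reverses, which feature of the cores is responsible, or how the change would behave on any third core.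

The cores of compound 1 and compound 3 differ in more than one place, so the compounds shown leave open which of those differences decides the outcome of the swap. They also leave open whether a plain phenyl group or a phenyl ring with a single chlorine, placed on the same ring nitrogen, would follow compound 2 or compound 4 on each core, and so whether the reversal is specific to the 2,3-dichlorophenyl group.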